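A benzyl swap with one measured neighbour

The compounds below may be only part of what the source reports. "The series", "measured", "known", "first", "only" and "open" are said of these compounds alone.

Values in a functional assay on CCRF-CEM cells (Homo sapiens) for antiproliferative activity, with a stated time of 72 h; on this read-out lower numbers stand for stronger inhibition and higher numbers for weaker inhibition:
- compound 1 `COc1ccccc1CNc1ncnc2c1ncn2[C@@H]1O[C@H](CO)[C@@H](O)[C@H]1O`: 3200 nM
- compound 2 `OC[C@H]1O[C@@H](n2cnc3c(NCc4cc(O)cc(O)c4)ncnc32)[C@H](O)[C@@H]1O`: "not determined" (no result reported)

Among the measured compounds shown here, only one of these two compounds has a number. For compound 2 the entry reads "not determined" (no result reported), so it has no place on the scale and cannot be ranked as stronger or weaker than anything else.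

The next compound, compound 3 `Cc1ccc(O)c(CNc2ncnc3c2ncn3[C@@H]2O[C@H](CO)[C@@H](O)[C@H]2O)c1`, keeps the shared core. For the measured compounds named here, the single structural change is 2-hydroxy-5-methylphenyl in place of 3,5-dihydroxyphenyl on a saturated chain carbon bound to a nitrogen on an aromatic ring. Put simply, 3,5-dihydroxybenzyl gives way to 2-hydroxy-5-methylbenzyl, so a hydroxy group remains in the name and a methyl group enters.

With no starting number, this step cannot be sized from the data. No step beyond the usual scatter is assumed in this assay, and no direction is favoured. Going by the values given here, the only measured anchor is compound 1 at 3200 nM, and that single value sets the expected range, which stays wide.

Compound 3 is estimated at 2800 nM (expected range 700 nM to 11000 nM).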

Compound 3, half-maximal inhibitory concentration: 1900 nM
Estimate against measurement, compound 3: 1.5-fold (0.17 log units) above, within the range that was stated.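

In this assay, among the compounds shown here, the step of a 1.7-fold lower number from compound 1 to compound 3 (0.23 log units; within the scatter) is the first comparison at this position that can be read from measured numbers. It shows that 2-hydroxy-5-methylphenyl in place of 2-methoxyphenyl, on a saturated chain carbon bound to a nitrogen on an aromatic ring, gives a difference no larger than repeated measurements of the same compound can produce, so on this read-out the two groups cannot be told apart. No measurement is at hand that would explain this result or link it to either group.

On these data alone, compound 2 has no number, so any step from it to compound 3 cannot be read, and the effect of 3,5-dihydroxyphenyl at this position remains unknown. Also open, as far as these compounds go, is whether a group of another kind on the phenyl ring, such as an amine or a carboxylic acid, would move the number beyond the scatter, since the groups with numbers here are only 2-methoxyphenyl and 2-hydroxy-5-methylphenyl.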